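A few compounds are considered here, and "the series" means these few. Any claim that something is new, unique, unknown or untested is made for them only; others in the source may bear on it.

In an assay on isolated protein for inhibition of histone deacetylase 8 (Homo sapiens), with a stated time of 1 h (on this read-out higher numbers stand for weaker inhibition and lower numbers for stronger inhibition), compound 1 `COc1cccc(NC(=O)COc2ccc3cc(/C=C4/SC(=O)NC4=O)ccc3c2)c1` gives 7600 nM. For compound 2 `Cc1ccc(NC(=O)COc2ccc3cc(/C=C4/SC(=O)NC4=O)ccc3c2)cc1Cl` the read-out is only a limit, > 50000 nM. The step of an at least 6.5-fold higher number from compound 1 to compound 2 (0.81 log units; beyond the scatter) rests on the limit of > 50000 nM in this assay, at which 1 of the 2 values shown sits, and places compound 2 at the weak end of the two numbers shown. Compound 3 `O=C(COc1ccc2cc(/C=C3/SC(=O)NC3=O)ccc2c1)Nc1cccc(Cl)c1` differs from compound 2 by hydrogen in place of methyl on an aromatic carbon, trimming 3-chloro-4-methylphenyl to 3-chlorophenyl. For the measured compounds named here, the one measured step, an at least 6.5-fold higher number from compound 1 to compound 2 (0.81 log units; beyond the scatter), exchanges the whole aryl group, so no measured step isolates the methyl. Compound 3 is expected at 30000 nM, range 8000 nM to 120000 nM, with a fair chance of another limit. The expected step is an at least 1.6-fold lower number from compound 2 to compound 3 (0.22 log units; that floor lies within the scatter).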

Compound 3, half-maximal inhibitory concentration: > 50000 nM
Compound 3: no number, only a limit; the forecaster's own chance of this, stated with the estimate: 45%; middle value at least 1.6-fold (0.22 log units) away from the limit.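

In this assay, the read-out for compound 3 is again only a limit, > 50000 nM. Without the methyl, the 3-chlorophenyl amide still gives an at least 6.5-fold higher number from compound 1 to compound 3 (0.81 log units; beyond the scatter), so chloro in place of methoxy on the aromatic carbon is enough for this loss, with no methyl required. The step from compound 2 to compound 3 cannot be read because both values are limits: the limit of > 50000 nM in this assay, at which 2 of the 3 values shown sit.

Going by these compounds, it remains open whether the methyl has any effect of its own in this assay. On these data alone, it is also open whether a hydroxy group or an amine in place of the methoxy of compound 1 would keep a measurable number.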